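The source may hold more compounds than are shown below. What is called first, only, known or untested is meant among the compounds shown, and "the series" means these compounds.

Measured so far:
Compound 1 `COC(=O)/C=C/C[C@H]1OCCC[C@@H]1O[Si](C)(C)C(C)(C)C` gives 77000 nM.
Compound 2 `COC(=O)/C=C/[C@H]1OCCC[C@@H]1O[Si](C)(C)C(C)(C)C` gives 69000 nM.

In a functional assay on HL-60 cells (Homo sapiens) for inhibition (on this read-out lower numbers stand for stronger inhibition of growth and higher numbers for weaker inhibition of growth), compound 2 holds the lowest of the two numbers, but its nearest neighbour is compound 1, and the gap from compound 1 to compound 2 a 1.1-fold lower number from compound 1 to compound 2 (0.05 log units; within the scatter) lies within the scatter. Compound 3 `CC(C)(C)[Si](C)(C)O[C@H]1CCCO[C@@H]1/C=C\CO` carries 3-hydroxyprop-1-en-1-yl in place of 2-(methoxycarbonyl)ethenyl on a saturated ring carbon. Among the compounds with values here, the only measured step, a 1.1-fold lower number from compound 1 to compound 2 (0.05 log units; within the scatter), also touched the group on that ring carbon and stayed within the scatter, so the change to compound 3 is expected to bring no step beyond the scatter, a 1.0-fold higher number from compound 2 to compound 3 (0.01 log units; within the scatter). Compound 3 is therefore estimated at 70000 nM, with a range from 20000 nM to 250000 nM.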

Compound 3, concentration for total growth inhibition: 64000 nM
Compound 3: the middle estimate sits 1.1-fold (0.04 log units) above what was measured; the range from low to high includes it.
By their numbers in this assay, from the lowest: compounds 3, 2 and 1 (each within the scatter of the next).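

In this assay, 3-hydroxyprop-1-en-1-yl in place of 2-(methoxycarbonyl)ethenyl gives a 1.1-fold lower number from compound 2 to compound 3 (0.03 log units; within the scatter) and, set against the 3-(methoxycarbonyl)prop-2-en-1-yl group, a 1.2-fold lower number from compound 1 to compound 3 (0.08 log units; within the scatter) on the same saturated ring carbon. The earlier pair compared only two methyl esters, whereas these steps show that a hydroxyl-bearing chain with a hydrogen-bond donor can replace the ester on this carbon and stay within the scatter. From the compounds shown here alone, it remains open whether an amine or a carboxylic acid at this position would bring a step beyond the scatter. Nothing available explains why these numbers stay so close.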